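A few compounds are considered here, and "the series" means these few. Any claim that something is new, unique, unknown or untested is made for them only; others in the source may bear on it.

Working notes on the series. In a functional assay on BXPC-3 cells (Homo sapiens) for inhibition, read by MTT assay, with a stated time of 7 days (a higher number here means a weaker inhibitor, a lower number a stronger inhibitor), compound 2 `CC(C)NS(=O)(=O)c1ccc(S(=O)(=O)N2CCC[C@@H](C(=O)N3CCN(c4nc(C(C)C)no4)CC3)C2)cc1` gives 2600 nM, the second highest of the three numbers in hand. Compound 1 `CCN(CC)C(=O)c1ccc(S(=O)(=O)N2CCC[C@@H](C(=O)N3CCN(c4nc(C(C)C)no4)CC3)C2)cc1` gives 1400 nM in this assay, and compound 3 `CCOC(=O)[C@@H]1CCCN(S(=O)(=O)c2ccc(S(=O)(=O)N(CC)CC)nc2)C1` gives 8000 nM. Within the data shown here, the one single-point step measured so far, a 1.9-fold higher number from compound 1 to compound 2 (0.27 log units; within the scatter), exchanged groups on the same aromatic carbon and stayed within the scatter. Compound 4 `CCC(CC)S(=O)(=O)c1ccc(S(=O)(=O)N2CCC[C@@H](C(=O)N3CCN(c4nc(C(C)C)no4)CC3)C2)cc1` differs from compound 2 by pentan-3-yl in place of isopropylamino on a sulfonyl sulfur. Among the measured compounds shown here, only a 1.9-fold higher number from compound 1 to compound 2 (0.27 log units; within the scatter) bears on this position, and it was small; no measured pair replaces the isopropylamino group with a carbon chain. A step of no clear size beyond the scatter is therefore expected in this assay. Compound 4 is estimated at 2000 nM, with a range of 700 nM to 6000 nM, which means a 1.3-fold lower number from compound 2 to compound 4 (0.11 log units; within the scatter).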

Compound 4, half-maximal inhibitory concentration: 120 nM
Compound 4: the middle estimate sits 17-fold (1.22 log units) above what was measured; the measured number lies below the stated range.
By their numbers in this assay, from the lowest: compound 4; then compounds 1 and 2 (each within the scatter of the next); then compound 3.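

In this assay the group on the sulfonyl sulfur matters far more than the earlier step suggested: pentan-3-yl in place of isopropylamino gives a 22-fold lower number from compound 2 to compound 4 (1.34 log units; beyond the scatter) and so separates two compounds that share the core. Against compound 1, (pentan-3-yl)sulfonyl in place of diethylcarbamoyl on the aromatic carbon gives a 12-fold lower number from compound 1 to compound 4 (1.07 log units; beyond the scatter) as well. No measurement on hand accounts for this gain.

Open, from the compounds shown here alone, is whether the gain follows the branched carbon chain or the loss of the sulfonamide nitrogen. An isopropyl or cyclohexyl group on the sulfonyl sulfur would separate the two.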